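Removing one methyl group from compound 3

The compounds below may be only part of what the source reports. "The series", "measured", "known", "first", "only" and "open" are said of these compounds alone.

Compound 3 `Cc1ccc(NC(=O)c2c(NC(=O)C(F)(F)F)sc3c2CCCCC3)cc1` gives > 50000 nM in an ADME assay on THP-1 cells (Homo sapiens) for cytotoxicity (on this read-out higher numbers stand for lower toxicity in this test and lower numbers for higher toxicity in this test), which is a limit of the assay and not a number. Compound 2 `COc1ccccc1NC(=O)c1c(NC(=O)C(F)(F)F)sc2c1CCCCC2` gives > 50000 nM, also a limit. Compound 3 therefore sits at the limit of > 50000 nM in this assay, at which 2 of the 3 values shown sit. Compound 1 `O=C(Nc1ccc(OC(F)(F)F)cc1)c1c(NC(=O)C(F)(F)F)sc2c1CCCCC2` gives a true number, 11900 nM.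

Compound 4 `O=C(Nc1ccccc1)c1c(NC(=O)C(F)(F)F)sc2c1CCCCC2` carries hydrogen in place of methyl on an aromatic carbon, para to a large group (hydrogen in place of methyl on an aromatic carbon). The closest measured change, also on an aromatic carbon, puts methyl in place of trifluoromethoxy and shows an at least 4.2-fold higher number from compound 1 to compound 3 (0.62 log units; beyond the scatter), beyond the scatter. The other measured change shows a step that the two limits leave unreadable from compound 2 to compound 3. Neither tests hydrogen directly. Only compound 1, which carries trifluoromethoxy, gives a number in this assay, and compound 4 lacks that group, so no step beyond the scatter is expected. The expected result is a number no higher from compound 3 to compound 4 (the limit leaves the size open), and a reading at the limit would be unsurprising. For compound 4 the estimate is 50000 nM, with an expected range of 20000 nM to 120000 nM.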

Compound 4, half-maximal cytotoxic concentration: > 50000 nM
Compound 4 gave a limit, no number; the forecaster's own chance of this, stated with the estimate: 65%; the middle value sits exactly at the limit.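

With hydrogen on this aromatic carbon, para to a large group, compound 4 stays at the limit of this assay, so the methyl group of compound 3 is not needed for that reading. Hydrogen in place of trifluoromethoxy gives an at least 4.2-fold higher number from compound 1 to compound 4 (0.62 log units; beyond the scatter), which matches what methyl in place of trifluoromethoxy showed, and compound 1 remains the only compound here with a true number: the limit of > 50000 nM in this assay, at which 3 of the 4 values shown sit.

The steps from compound 2 and from compound 3 to compound 4 cannot be read, as both ends of each are limits. From the compounds shown here alone, how far the true values of compound 2, compound 3 and compound 4 lie past the limit remains open. So does whether an amine, a carboxylic acid or a longer chain on this carbon would bring the reading down to a true number.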